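This account rests on a few compounds, and the source may have more. Where it says the series, first, only, none or still open, it means among the compounds named here.

In a functional assay on MDA-MB-231 cells (Homo sapiens) for antiproliferative activity, read by MTT assay, with a stated time of 24 h (a lower number here means a stronger inhibitor, a higher number a weaker inhibitor), compound 3 `O=C(O)CC(NS(=O)(=O)c1ccccc1Br)c1ccc(Cl)cc1Cl` gives only a limit, > 100000 nM, not a number. The change to compound 4 `N#Cc1ccc(S(=O)(=O)NC(CC(=O)O)c2ccc(Cl)cc2Cl)cc1` is 4-cyanophenyl in place of 2-bromophenyl on a sulfonyl sulfur. For the measured compounds named here, no measured step covers this swap directly. Compound 1 `N#Cc1ccc(S(=O)(=O)NC(CC(=O)O)c2ccccc2)cc1` carries 4-cyanophenyl and gives 48700 nM. Compound 2 `N#Cc1ccc(S(=O)(=O)NC(CC(=O)O)c2ccccc2F)cc1` carries it too and gives 69700 nM. Going by the values given here, the one measured step, a 1.4-fold higher number from compound 1 to compound 2 (0.16 log units; within the scatter), is fluoro in place of hydrogen on an aromatic carbon and lies within the scatter. A value for compound 4 near those of compound 1 and compound 2 is therefore expected. The expected change in this assay is an at least 1.5-fold lower number from compound 3 to compound 4 (0.18 log units; that floor lies within the scatter), towards a lower number, its true size left open by the limit. Compound 4 is estimated at 65000 nM, with an expected range of 30000 nM to 100000 nM.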

Compound 4, half-maximal inhibitory concentration: 12600 nM
Estimate against measurement, compound 4: 5.2-fold (0.71 log units) above; the whole stated range lies above it.
By their numbers in this assay, from the lowest: compound 4; then compounds 1 and 2 (each within the scatter of the next). At a limit, above all of these: compound 3.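

In this assay, 4-cyanophenyl in place of 2-bromophenyl on a sulfonyl sulfur gives an at least 7.9-fold lower number from compound 3 to compound 4 (0.89 log units; beyond the scatter), a step whose true size stays open, as compound 3 holds only a limit: the limit of > 100000 nM in this assay, at which 1 of the 4 values shown sits.

With 4-cyanophenyl held, 2,4-dichlorophenyl on the saturated chain carbon gives a 5.5-fold lower number from compound 2 to compound 4 (0.74 log units; beyond the scatter) and a 3.9-fold lower number from compound 1 to compound 4 (0.59 log units; beyond the scatter). The aryl group on that carbon therefore moves the number beyond the scatter, which the fluoro step did not show.

Which chlorine of 2,4-dichlorophenyl carries these steps stays open. So does the effect of a methyl ester in place of the carboxylic acid.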